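The source may hold more compounds than are shown below. What is called first, only, known or untested is meant among the compounds shown, and "the series" means these compounds.

Compound 1 `Cc1nc(-c2ccccc2)n2c(O)nncc12` in a functional assay for inhibition, with Homo sapiens as the target (a higher number here means a weaker inhibitor, a lower number a stronger inhibitor), gives > 48000 nM, which is a limit of the measurement rather than a number.
Compound 2 `Sc1nncc2cnc(-c3ccccc3)n12` in this assay gives > 48000 nM, again only a limit.

Compound 2 thus stands at the edge of what this assay can report, a position shared by the other measured compound, as the limit of > 48000 nM in this assay, at which 2 of the 2 values shown sit, shows. Compound 3 `Oc1nncc2cnc(-c3ccccc3)n12` differs from compound 2 by one change: hydroxy in place of sulfanyl on an aromatic carbon. Going by the values given here, no measured pair shows such a step, so no step beyond the scatter is expected, and the change from compound 2 to compound 3 is estimated as a step that the limit leaves unreadable from compound 2 to compound 3. Compound 3 is therefore expected near 60000 nM, within 15000 nM to 250000 nM, most likely again reported only as a limit.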

Compound 3, half-maximal inhibitory concentration: > 48000 nM
Compound 3 ended at the assay's limit; the forecaster's own chance of this, stated with the estimate: 80%; the middle value is on the limit's open side.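

Going by these compounds alone, no step from compound 1 or compound 2 to compound 3 can be read, because all three stop at the same limit: the limit of > 48000 nM in this assay, at which 3 of the 3 values shown sit.

On these data alone, how strongly any of them inhibits, and whether sulfanyl, hydroxy or methyl changes that, remains open.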